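Propanoyl amide to urea on a shared core

The compounds below may be only part of what the source reports. "The series", "measured", "known", "first", "only" and "open" are said of these compounds alone.

In an assay on HEK293 cells for inhibition of Indoleamine 2,3-dioxygenase 1 (Homo sapiens), tested at 10 uM (on this read-out lower numbers stand for less inhibition and higher numbers for more inhibition at the one concentration tested (going by the name of the read-out)), three compounds on one shared core have been measured: compound 1 `CC(=O)N1CCc2cc(CNC(=O)c3cccs3)ccc21` gives 72%, compound 3 `CC(C)C(=O)N1CCc2cc(CNC(=O)c3ccccc3)ccc21` gives 100%, and compound 2 `CCC(=O)NCc1ccc2c(c1)CCN2C(=O)c1ccccc1` gives 41%, the lowest of the three, with compound 1 nearest and compound 3 furthest, both gaps beyond the scatter. Compound 4 `CC(C)NC(=O)NCc1ccc2c(c1)CCN2C(=O)c1ccccc1` has not yet been measured in this assay. It differs from compound 2 by isopropylamino in place of ethyl on a carbonyl carbon. For the measured compounds named here, no measured pair differs at this carbonyl carbon, so the direction of the step is open. The step expected is a number 4 percentage points higher from compound 2 to compound 4 (within the scatter), and it may well stay within the scatter. Compound 4 is therefore estimated to give 45%, in a range from 20% to 75%.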

Compound 4, a percentage reported as inhibition, at one concentration (the size of the read-out at that concentration, not a potency): 45%
Estimate against measurement, compound 4: no gap at the digits printed; the measured number falls inside the stated range.
By their numbers in this assay, from the lowest: compounds 2 and 4 (each within the scatter of the next); then compound 1; then compound 3.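

In this assay, for the compounds shown here, a number 4 percentage points higher from compound 2 to compound 4 (within the scatter) gives the first reading at this carbonyl carbon, where isopropylamino replaces ethyl. Turning the propanoyl amide into the urea, with two more heavy atoms and one more hydrogen-bond donor in the group, therefore leaves the number within the scatter. Nothing measured here accounts for how small this step is.

From the compounds shown here alone, whether a dimethylamino group or a longer chain such as butyl on the same carbonyl carbon would move the number remains open. So does whether the same change would behave alike on the other compounds of the series.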